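The compounds below may be only part of what the source reports. "The series", "measured", "known", "first", "only" and "open" are said of these compounds alone.

Compound 1, `Cc1cc(=O)c2ccc(O)c(CN(Cc3ccccc3)Cc3ccccc3)c2o1`: 11.9 ug/mL
Compound 2, `COc1ccc(CN(Cc2ccccc2)Cc2c(O)ccc3c(=O)cc(C)oc23)cc1`: 14.1 ug/mL
Compound 3, `CCN(Cc1ccc(OC)cc1)Cc1c(O)ccc2c(=O)cc(C)oc12`: 38.7 ug/mL

The three measured compounds share one core and differ only in the groups on the amine nitrogen. In a functional assay on A549 cells (Homo sapiens) for inhibition, read by sulforhodamine B assay, with a stated time of 72 h (a higher number here means a weaker inhibitor, a lower number a stronger inhibitor), compound 3 gives the highest number of the three; the nearest measured value is that of compound 2, reached by the step of a 2.7-fold higher number from compound 2 to compound 3 (0.44 log units; beyond the scatter), and compound 1 lies further off. Compound 4, `COc1ccc(CN(Cc2ccc([N+](=O)[O-])cc2)Cc2c(O)ccc3c(=O)cc(C)oc23)cc1`, has not been measured. It differs from compound 3 by 4-nitrophenyl in place of methyl on a saturated chain carbon bound to an amine nitrogen. Within the data shown here, two measured steps bear on this change. The step of a 2.7-fold higher number from compound 2 to compound 3 (0.44 log units; beyond the scatter) shows that taking the phenyl away at this position made the compound a weaker inhibitor, so putting an aryl group back is expected to recover most of that loss. The step of a 1.2-fold higher number from compound 1 to compound 2 (0.07 log units; within the scatter) shows that a substituent on such an aromatic ring changed nothing beyond the scatter. Compound 4 is therefore expected to move back toward compound 2, by a 2.6-fold lower number from compound 3 to compound 4 (0.41 log units; beyond the scatter). The estimated value of compound 4 in this assay is 15 ug/mL, within a range from 7 ug/mL to 32 ug/mL.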

Compound 4, half-maximal inhibitory concentration: 24.5 ug/mL
Compound 4: middle estimate off by 1.6-fold (0.21 log units), on the low side, and the stated range covers the measured number.
By their numbers in this assay, from the lowest: compounds 1, 2, 4 and 3 (each within the scatter of the next, the first and the last beyond it).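

In this assay, 4-nitrophenyl in place of methyl on a saturated chain carbon bound to an amine nitrogen gives a 1.6-fold lower number from compound 3 to compound 4 (0.20 log units; within the scatter) and so cannot be told apart from compound 3 at this position. Nitro in place of hydrogen on an aromatic carbon gives a 1.7-fold higher number from compound 2 to compound 4 (0.24 log units; within the scatter) and so cannot be told apart from compound 2 either, even though compound 2 and compound 3 themselves stand beyond the scatter of each other. Compound 4 thus falls within reach of both neighbours, and nitro joins methoxy as a ring substituent whose step stays within the scatter.

Still open, on these data alone, is whether an amine or a carboxylic acid on that ring, or a longer chain such as propyl in place of the ethyl of compound 3, would give a step beyond the scatter. Nothing shown here accounts for these numbers.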